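The source may report more compounds than this note shows. Statements on the series, on what has been measured and on what is new or still open speak of the compounds shown alone.

The measured compounds, all read in a functional assay on KYSE-410 cells (Homo sapiens) for antiproliferative activity, read by MTT assay, with a stated time of 72 h; a lower number here means a stronger inhibitor, a higher number a weaker inhibitor:
Compound 1, `O=C(Nc1ccc(F)cc1)c1ccnc2cc(Br)ccc12`, gives only a limit in this assay, > 20000 nM.
Compound 2, `COc1ccc(NC(=O)c2cc(=O)[nH]c3cc(Br)ccc23)cc1`, likewise gives only a limit, > 20000 nM.
Compound 3, `COc1ccc(-c2ccc3c(C(=O)Nc4cccc(F)c4)cc(=O)[nH]c3c2)cc1`, gives a number, 18000 nM.

Compound 1 and compound 2 sit at the limit of > 20000 nM in this assay, at which 2 of the 3 values shown sit. Compound 3 is therefore the only one of the three with a reported number, 18000 nM, and it cannot be ranked against the other two beyond the fact that a number was obtained at all. The unmeasured compound 4, `O=C(Nc1cccc(F)c1)c1cc(=O)[nH]c2cc(-c3ccc(F)nc3)ccc12`, differs from compound 3 in one place: 6-fluoropyridin-3-yl in place of 4-methoxyphenyl on an aromatic carbon. The change sits on an aromatic carbon of a six-membered aromatic ring of carbon only, part of a fused or bridged system of two rings, meta to a fused ring and para to a fused ring. For the measured compounds named here, no step between measured compounds is available to calibrate such a swap, and the two limits give no direction. The estimate for this step is a 1.2-fold lower number from compound 3 to compound 4 (0.08 log units; within the scatter), which is expected to lie within the usual scatter rather than beyond it. Compound 4 is accordingly expected to give about 15000 nM in this assay, with a range from 5000 nM to 40000 nM, and a real chance that only a limit is returned.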

Compound 4, half-maximal inhibitory concentration: > 20000 nM
Compound 4 was reported as a limit; the forecaster's own chance of this, stated with the estimate: 40%; middle value at least 1.3-fold (0.12 log units) from the limit.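

In this assay, 6-fluoropyridin-3-yl in place of 4-methoxyphenyl gives an at least 1.1-fold higher number from compound 3 to compound 4 (0.04 log units; that floor lies within the scatter), the only step shown between two compounds that differ in one place. It shows that this swap on the aromatic carbon, meta to a fused ring and para to a fused ring, did not lower the number, but the step is a floor and how far compound 4 lies from compound 3 cannot be read. With this result, the one number obtained, for compound 3, stands alone among limits: the limit of > 20000 nM in this assay, at which 3 of the 4 values shown sit.

Going by these compounds, what a plain phenyl, an aminophenyl or a benzoic acid group on this carbon would give in this assay stays open, and so does whether any group here can bring the number well clear of the limit. Also open, on these data alone, is what the ring nitrogen and the fluorine each contribute, as the two enter together in compound 4, and a pyridin-3-yl without the fluorine or a 4-fluorophenyl would be needed to separate them.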